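The source may report more compounds than this note shows. Statements on the series, on what has been measured and on what is new or still open speak of the compounds shown alone.

Measured in a functional assay on MCF7 cells (Homo sapiens) for cytotoxicity, read by MTT assay, with a stated time of 72 h; a lower number here means a stronger inhibitor, a higher number a weaker inhibitor:
- compound 1 `O=C1C(=Cc2ccc(F)cc2)C(=O)N(c2ccc(Cl)cc2)N1c1ccc(Cl)cc1` gives 31400 nM
- compound 2 `O=C1C(=Cc2ccc(Br)cc2)C(=O)N(c2ccc(Cl)cc2)N1c1ccc(Cl)cc1` gives 30400 nM
- compound 3 `O=C1C(=Cc2cccc(Cl)c2)C(=O)N(c2ccc(Cl)cc2)N1c1ccc(Cl)cc1` gives 18300 nM

Compound 3 is not separated from the other two: the steps (a 1.7-fold lower number from compound 1 to compound 3 (0.23 log units; within the scatter)) and (a 1.7-fold lower number from compound 2 to compound 3 (0.22 log units; within the scatter)) both stay within the scatter, as does the step (a 1.0-fold lower number from compound 1 to compound 2 (0.01 log units; within the scatter)) between the other pair. Compound 4 `COc1ccccc1C=C1C(=O)N(c2ccc(Cl)cc2)N(c2ccc(Cl)cc2)C1=O` has 2-methoxyphenyl in place of 3-chlorophenyl on a double-bonded chain carbon bound to a double-bonded ring carbon. Going by the values given here, the group at this place also differs in the first two steps, but none of the measured compounds carries a methoxy group, so the guide is only indirect. In this assay no step beyond the scatter is expected, and no direction is favoured. The expected step is a 1.3-fold higher number from compound 3 to compound 4 (0.12 log units; within the scatter) and lies within the scatter. The estimate for compound 4 is 24000 nM and runs from 9000 nM to 60000 nM as the expected range.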

Compound 4, half-maximal inhibitory concentration: 26300 nM
Compound 4: the middle estimate sits 1.1-fold (0.04 log units) below what was measured; measured number inside the range.
By their numbers in this assay, from the lowest: compounds 3, 4, 2 and 1 (each within the scatter of the next).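

In this assay, 2-methoxyphenyl on the double-bonded chain carbon gives a number that stays within the scatter of all three halogen-bearing compounds, as the steps (a 1.4-fold higher number from compound 3 to compound 4 (0.16 log units; within the scatter)), (a 1.2-fold lower number from compound 2 to compound 4 (0.06 log units; within the scatter)) and (a 1.2-fold lower number from compound 1 to compound 4 (0.08 log units; within the scatter)) show. The series therefore now includes a group with oxygen and a hydrogen-bond acceptor in place of halogen, and the number still does not separate from the others. Nothing measured here explains this result. Going by these compounds, it remains open whether an amine or a carboxylic acid on this aromatic ring would move the number beyond the scatter.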